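The source may hold more compounds than are shown below. What is called first, only, known or untested is meant among the compounds shown, and "the series" means these compounds.

Measured so far:
- compound 1, `COc1ccc2ncc(S(=O)(=O)c3ccc(OC)c(Cl)c3)c(N3CCC(C)CC3)c2c1`: 21%
- compound 2, `COc1ccc(S(=O)(=O)c2cnc3ccc(F)cc3c2N2CCC(C)CC2)cc1Cl`: 82%
- compound 3, `COc1ccc(S(=O)(=O)c2cnc3ccc(C)cc3c2N2CCC(C)CC2)cc1Cl`: 93%

In an assay on isolated protein for displacement of a labelled ligand from metabotropic glutamate receptor 5 (Homo sapiens), with a stated time of 60 min, tested at 1 uM (a higher number here means more inhibition at the concentration tested (going by the name of the read-out), a lower number less inhibition), compound 1 gives the lowest of the three numbers. Its nearest neighbour is compound 2, a step of a number 61 percentage points higher from compound 1 to compound 2 (beyond the scatter) away, and the furthest is compound 3, at a number 72 percentage points higher from compound 1 to compound 3 (beyond the scatter); between those two lies a number 11 percentage points higher from compound 2 to compound 3 (beyond the scatter).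

Compound 4, `COc1ccc2ncc(S(=O)(=O)c3cccc(Cl)c3)c(N3CCC(C)CC3)c2c1`, is not yet measured. It differs from compound 1 in one place: hydrogen in place of methoxy on an aromatic carbon. Read one bond further out, 3-chloro-4-methoxyphenyl becomes 3-chlorophenyl.

Among the compounds with values here, none of the measured steps touches this ring: the steps from compound 1 to compound 2 and to compound 3 replace a methoxy on the shared core, not the one sitting ortho to the chloro group. They do show that swapping a methoxy for a smaller group elsewhere raised inhibition strongly, but that carries only loosely to this position. The expectation for compound 4 is therefore a step of a number 19 percentage points higher from compound 1 to compound 4 (beyond the scatter) in this assay, upward but uncertain, with the estimate 40% in the range 10% to 75%.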

Compound 4, a percentage reported as inhibition, at one concentration (the size of the read-out at that concentration, not a potency): -3%
Compound 4: middle estimate off by 43 percentage points, on the high side; the whole stated range lies above it.
By their numbers in this assay, from the lowest: compound 4; then compound 1; then compound 2; then compound 3.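

Taking the methoxy off the 3-chloro-4-methoxyphenyl ring does not help: in this assay the change to 3-chlorophenyl gives a number 24 percentage points lower from compound 1 to compound 4 (beyond the scatter), so at this carbon, ortho to a chloro group, the methoxy goes with more inhibition rather than less. On the shared core, replacing a methoxy with fluoro or methyl raised the number, whereas replacing this one with hydrogen lowered it, so the effect of removing a methoxy depends on where it sits in these compounds. No measurement available here explains the drop.

The compounds shown compare only methoxy and hydrogen on this carbon, so it stays open how an ethoxy, a hydroxyl or an amine would behave there. Also open, on these data alone, is whether the fluoro or methyl on the core would still raise the number in a compound without this methoxy.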